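From 4-methylphenyl to 4-fluorophenyl in a cytotoxicity series

A few compounds are considered here, and "the series" means these few. Any claim that something is new, unique, unknown or untested is made for them only; others in the source may bear on it.

Compound 1 `CNC(=O)c1cc(Oc2ccc(NC(=O)c3cc(-c4ccc(Cl)cc4)ncn3)cc2F)ccn1` gives > 100000 nM as a limit
Compound 2 `CNC(=O)c1cc(Oc2ccc(NC(=O)c3cc(-c4ccc(C(F)(F)F)cc4)ncn3)cc2F)ccn1` gives > 100000 nM as a limit
Compound 3 `CNC(=O)c1cc(Oc2ccc(NC(=O)c3cc(-c4ccc(C)cc4)ncn3)cc2F)ccn1` gives 40200 nM as a number
Compound 4 `CNC(=O)c1cc(Oc2ccc(NC(=O)c3cc(-c4ccc(F)cc4)ncn3)cc2F)ccn1` has no value yet

Going by the values given here, all of these values come from a functional assay on PC-3 cells (Homo sapiens) for cytotoxicity, read by MTT assay, with a stated time of 72 h (on this read-out lower numbers stand for stronger inhibition and higher numbers for weaker inhibition), and compound 3 holds the only actual number among them. The next step leads to compound 4, with fluoro in place of methyl on an aromatic carbon, and fluoro in place of methyl on an aromatic carbon gives the count of that change. Among the compounds with values here, two measured steps bear on it. Methyl in place of chloro gave an at least 2.4-fold lower number from compound 1 to compound 3 (0.39 log units; beyond the scatter) and methyl in place of trifluoromethyl gave an at least 2.4-fold lower number from compound 2 to compound 3 (0.39 log units; beyond the scatter) so both replacements of methyl's neighbours in the series ended at compound 3 with the lower number. Fluoro itself is untested here, so only a small rise is expected, near the usual scatter, and a result reported only as a limit would be no surprise. The expected step is a 1.7-fold higher number from compound 3 to compound 4 (0.24 log units; within the scatter) as an estimate. The estimate for compound 4 is 70000 nM with an expected range of 30000 nM to 120000 nM in this assay when tested.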

Compound 4, half-maximal inhibitory concentration: > 100000 nM
Compound 4: no number, only a limit; the forecaster's own chance of this, stated with the estimate: 40%; middle value at least 1.4-fold (0.15 log units) away from the limit.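

In this assay, fluoro in place of methyl on the aromatic carbon para to a large group gives an at least 2.4-fold higher number from compound 3 to compound 4 (0.39 log units; beyond the scatter), so even this replacement does not keep the activity seen with methyl. Of the four groups shown at this position, only the 4-methylphenyl of compound 3 gives an actual number, and the other three compounds stop at the same limit of the assay: the limit of > 100000 nM in this assay, at which 3 of the 4 values shown sit. The steps among compound 1, compound 2 and compound 4 cannot be read, as all three values are limits and not numbers.

Going by these compounds, how far these three compounds lie past the limit stays open. So does whether another group at this position, such as an amine, a methoxy group or a longer chain like ethyl, would give a lower number than methyl does.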